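This account rests on a few compounds, and the source may have more. Where it says the series, first, only, none or still open, it means among the compounds named here.

In a functional assay on A-375 cells (Homo sapiens) for cytotoxicity, read by MTT assay, with a stated time of 72 h (on this read-out higher numbers stand for weaker inhibition and lower numbers for stronger inhibition), compound 2 `N/C(=N\NC(=S)N1CCCCC1)c1ccccn1` gives 680 nM, the lowest of the two numbers recorded so far. Compound 1 `Cc1ccnc(/C(N)=N/NC(=S)N2CCOCC2)c1` gives 1600 nM in this assay, a number beyond the scatter away from that of compound 2; the two compounds differ in more than one place, so the two values say nothing about either change on its own. Compound 3 `Cc1ccnc(/C(N)=N/NC(=S)N2CCCCC2)c1` arises from compound 2 by methyl in place of hydrogen on an aromatic carbon. Going by the values given here, no single-change step is available to anchor this change, so the account expects only a modest movement in this assay: the expected step of a 1.2-fold higher number from compound 2 to compound 3 (0.07 log units; within the scatter) lies within the scatter. Compound 3 is therefore estimated at 800 nM, with a range from 300 nM to 2200 nM.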

Compound 3, half-maximal inhibitory concentration: 1900 nM
Compound 3: middle estimate off by 2.4-fold (0.38 log units), on the low side; measured number inside the range.
By their numbers in this assay, from the lowest: compound 2; then compounds 1 and 3 (each within the scatter of the next).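

In this assay, methyl on this aromatic carbon, opposite the ring nitrogen, gives a 2.8-fold higher number from compound 2 to compound 3 (0.45 log units; beyond the scatter), so this position is not indifferent to the change, and the step runs toward weaker inhibition. With the methyl present, piperidin-1-yl in place of morpholin-4-yl on the thiocarbonyl carbon gives a 1.2-fold higher number from compound 1 to compound 3 (0.07 log units; within the scatter), which lies within the scatter. Nothing available explains the methyl step. From the compounds shown here alone, whether chlorine or methoxy at this position would move the number in the same way stays open, as does whether the two rings on the thiocarbonyl carbon remain level without the methyl.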